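Swapping the Oxopyrrolidinyl Group for an Aromatic Ring

This account rests on a few compounds, and the source may have more. Where it says the series, first, only, none or still open, it means among the compounds named here.

Measured compounds:
compound 1, `Cc1ccc2c(c1)[C@@H](N1CCCCC1=O)[C@H](O)C(C)(C)O2`: 1200 nM
compound 2, `CCc1ccc2c(c1)[C@@H](N1CCCC1=O)[C@H](O)C(C)(C)O2`: 2680 nM
compound 3, `CC1(C)C=C(N2CCCC2=O)c2cc(C#N)ccc2O1`: 1570 nM

All three numbers come from a functional assay (trachea) for inhibition, with Cavia porcellus as the target; a lower number here means a stronger inhibitor, a higher number a weaker inhibitor. Compound 3 sits second highest of the three; its nearest neighbour is compound 1 and its furthest is compound 2, yet both gaps fall within the usual scatter of repeated measurements, so the three compounds cannot be ranked against one another on these numbers.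

Compound 4, `CC1(C)C=C(n2ccccc2=O)c2cc(C#N)ccc2O1`, has not yet been measured. It differs from compound 3 in one place: a group of 7 heavy atoms (5 carbon, 1 nitrogen, 1 oxygen; one six-membered aromatic ring with 1 hetero atom) in place of a group of 6 heavy atoms (4 carbon, 1 nitrogen, 1 oxygen; one five-membered non-aromatic ring with 1 hetero atom), on a double-bonded ring carbon. For the measured compounds named here, no measured pair shows what such a swap does, so there is no step to lean on. With nothing to point either way, the change is expected to move the number by less than the scatter, in no firm direction. Compound 4 is therefore expected to give about 1800 nM, with a range from 600 nM to 5500 nM. The estimate means an expected 1.1-fold higher number from compound 3 to compound 4 (0.06 log units; within the scatter).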

Compound 4, half-maximal inhibitory concentration: 89 nM
Compound 4: middle estimate off by 20-fold (1.31 log units), on the high side; measured number below the stated range.
By their numbers in this assay, from the lowest: compound 4; then compounds 1, 3 and 2 (each within the scatter of the next, the first and the last beyond it).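

At the double-bonded ring carbon, this assay responds strongly to the group attached: putting a six-membered aromatic ring with 1 hetero atom in place of 2-oxopyrrolidin-1-yl gives an 18-fold lower number from compound 3 to compound 4 (1.25 log units; beyond the scatter) with only that one place changed. Compounds 1, 2 and 3 all carry a non-aromatic ring at this place, so they could not show how far an aromatic ring there moves the number. Nothing measured here bears on what lies behind this large step.

On these data alone, it remains open whether a plain phenyl ring or a pyridine ring without the carbonyl would give a number like that of compound 4, or whether the ring's carbonyl is needed as well. As far as these compounds go, it is also open whether the same swap would have a similar effect on the core of compound 1, which carries a hydroxyl group and a methyl group rather than a nitrile.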